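Urea nitrogen substituent and half-life in human microsomes

A few compounds are considered here, and "the series" means these few. Any claim that something is new, unique, unknown or untested is made for them only; others in the source may bear on it.

Three measured compounds share one core and differ mainly in the group on the outer nitrogen of an aryl urea. Compound 1 `O=C(Nc1ccccc1)Nc1ccc(-c2nc(N3CC4CCC(C3)O4)c3cnn(C4CCC5(CC4)OCCO5)c3n2)cc1` carries phenyl there; in an in vitro ADME assay on microsomes (Homo sapiens) for metabolic stability (on this read-out lower numbers stand for a shorter-lived compound and higher numbers for a longer-lived compound), compound 1 gives 0.217 h. Compound 3 `O=C(Nc1ccc(-c2nc(N3CC4CCC(C3)O4)c3cnn(C4CCC5(CC4)OCCO5)c3n2)cc1)NC1CC1` carries cyclopropyl; in this assay compound 3 gives 0.15 h. The step of a 1.4-fold lower number from compound 1 to compound 3 (0.16 log units; within the scatter) is within the scatter, so compound 3 and compound 1 sit at the same level and no order between them can be read. Compound 2 `CNC(=O)Nc1ccc(-c2nc(N3CC4CCC(C3)O4)c3cnn(C4CCC5(CC4)OCCCO5)c3n2)cc1`, which differs from both in more than one place, reaches only a limit in this assay: compound 2 gives > 0.5 h, which is the limit of > 0.5 h in this assay, at which 1 of the 3 values shown sits. Compound 3 thus stands beside compound 1, with compound 2 beyond a limit.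

Compound 4 `O=C(Nc1ccc(-c2nc(N3CC4CCC(C3)O4)c3cnn(C4CCC5(CC4)OCCO5)c3n2)cc1)Nc1cccnc1` differs from compound 3 in one place: pyridin-3-yl in place of cyclopropyl on an amide-type nitrogen. Going by the values given here, the only measured step that bears on it is the exchange of phenyl for cyclopropyl on the same nitrogen, which moved the number by a 1.4-fold lower number from compound 1 to compound 3 (0.16 log units; within the scatter). Among the compounds with values here, no measured step carries a pyridin-3-yl group. The step of a 1.3-fold higher number from compound 3 to compound 4 (0.12 log units; within the scatter) is therefore expected to stay within the scatter, returning toward the level of compound 1 rather than beyond it. Compound 4 is estimated at 0.2 h, with a range from 0.1 h to 0.45 h.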

Compound 4, half-life: 0.217 h
Compound 4: the middle estimate sits 1.1-fold (0.04 log units) below what was measured; measured number inside the range.
By their numbers in this assay, from the lowest: compounds 3, 1 and 4 (each within the scatter of the next). At a limit, above all of these: compound 2.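

In this assay, pyridin-3-yl in place of cyclopropyl on the amide-type nitrogen gives a 1.4-fold higher number from compound 3 to compound 4 (0.16 log units; within the scatter), and pyridin-3-yl in place of phenyl on that nitrogen gives no change at the digits printed from compound 1 to compound 4 (within the scatter). Compound 1, compound 3 and compound 4 therefore sit at one level, so in these three compounds neither a six-membered aromatic ring in place of a three-membered non-aromatic ring of carbon only, nor a ring nitrogen in the six-membered aromatic ring, moves the half-life beyond the scatter. Nothing at hand bears on why these three groups read alike.

Compound 2 gives > 0.5 h, which is a limit, and it differs from the other compounds in more than one place, so its reading cannot be assigned to the group on the urea nitrogen alone. Going by these compounds, it remains open whether an aliphatic amine, a carboxylic acid or a longer alkyl chain on this nitrogen would leave the level shared by compound 1, compound 3 and compound 4.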